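Swapping Hydroxy for Amino in Two Related Cores

This account rests on a few compounds, and the source may have more. Where it says the series, first, only, none or still open, it means among the compounds named here.

Three compounds have been measured in a functional assay on HeLa cells (Homo sapiens) for antiproliferative activity, read by MTT assay, with a stated time of 48 h; a higher number here means a weaker inhibitor, a lower number a stronger inhibitor:

Compound 1 `C=C(c1ccc(OC)cc1NC(=O)CO)c1ccc(OC)c2c1OC(C)(C)C=C2` gives 40 nM.
Compound 2 `C=C(c1ccc2c(c1)C=CC(C)(C)O2)c1ccc(OC)cc1NC(=O)CO` gives 100 nM.
Compound 3 `C=C(c1ccc(OC)cc1NC(=O)CN)c1ccc(OC)c2c1OC(C)(C)C=C2` gives 120 nM.

Compound 1 and compound 3 share one core; compound 2 belongs to a second core, and the difference between the two cores is not broken down here. Compound 1 gives a lower number than compound 2, while compound 2 and compound 3 are within the scatter of each other, so no order between those two can be read. Within the first core, compound 3 differs from compound 1 by a single change, (amino in place of hydroxy on a saturated chain carbon bound to a carbonyl carbon), and that change produced a 3.0-fold higher number from compound 1 to compound 3 (0.48 log units; beyond the scatter).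

Compound 4 `C=C(c1ccc2c(c1)C=CC(C)(C)O2)c1ccc(OC)cc1NC(=O)CN` is built from compound 2 by the same change, (amino in place of hydroxy on a saturated chain carbon bound to a carbonyl carbon), at the same place. Among the measured compounds shown here, the only guide available is the one measured case of this change in the neighbouring core, and the expectation rests on carrying that step over to compound 2, whose value in this assay is 100 nM. The step expected is a 3.0-fold higher number from compound 2 to compound 4 (0.48 log units; beyond the scatter), with extra room: a single earlier instance cannot show how steady the change is across cores. Compound 4 is therefore estimated to give about 300 nM, most likely between 140 nM and 700 nM.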

Compound 4, half-maximal inhibitory concentration: 160 nM
Compound 4: the middle estimate sits 1.9-fold (0.27 log units) above what was measured; the range from low to high includes it.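

In this assay, amino in place of hydroxy on a saturated chain carbon bound to a carbonyl carbon gives a 1.6-fold higher number from compound 2 to compound 4 (0.20 log units; within the scatter), so on this core the effect of the swap cannot be told apart from the ordinary spread of repeat measurements. Set beside the earlier case, the two steps cannot be told apart either, so nothing here indicates that the two cores respond differently to the swap: the same change on two cores in this assay, a 3.0-fold higher number (0.48 log units; beyond the scatter) from compound 1 to compound 3 and a 1.6-fold higher number (0.20 log units; within the scatter) from compound 2 to compound 4, 1.9-fold (0.27 log units) apart, within the scatter of two such steps

This does not show that the change carries over with a fixed size, since there are only two cases, and only one of them is clear of the scatter on its own; agreement within the scatter is a failure to find a difference, not proof that the cores behave alike. 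

The compounds shown hold only hydroxy or amino at this place, so it stays open how a methoxy group, a dimethylamino group, a carboxylic acid or a longer chain ending in an amine would behave there. From the compounds shown here alone, it also stays open whether the same swap would give a similar step on a third core.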